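Difluoromethyl against trifluoromethyl on the sulfonyl group

A few compounds are considered here, and "the series" means these few. Any claim that something is new, unique, unknown or untested is made for them only; others in the source may bear on it.

Measured so far:
compound 1 `O=S(=O)(C(F)F)N1CCN(c2ccc(/C=C/c3cc(F)cc(Cn4ccnc4)c3)cc2)CC1`, 5 nM
compound 2 `O=S(=O)(C(F)F)N1CCN(c2ccc(/C=C/c3cc(Cl)cc(-c4ccncc4)c3)cc2)CC1`, 5 nM
compound 3 `O=S(=O)(N1CCN(c2ccc(/C=C/c3cc(F)cc(-c4ccncc4)c3)cc2)CC1)C(F)(F)F`, 2 nM

In an assay on cells for inhibition of steroid 17-alpha-hydroxylase/17,20 lyase (Homo sapiens), read by scintillation counting, with stated times of 60 min and 4 h (a lower number here means a stronger inhibitor, a higher number a weaker inhibitor), compound 3 gives 2 nM, the lowest of the three numbers. Both other compounds sit at the same distance from it, beyond the scatter: compound 1 gives 5 nM and compound 2 gives 5 nM in this assay.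

Compound 4 `O=S(=O)(C(F)F)N1CCN(c2ccc(/C=C/c3cc(F)cc(-c4ccncc4)c3)cc2)CC1` has not been measured. It differs from compound 3 in one place: hydrogen in place of fluoro on a saturated chain carbon bound to two fluorine atoms and a sulfonyl sulfur. Read one bond further out, the (trifluoromethyl)sulfonyl group of compound 3 becomes the (difluoromethyl)sulfonyl group in compound 4. Within the data shown here, no measured pair shows this change on its own. Among the measured compounds shown here, compound 1 and compound 2 both carry the (difluoromethyl)sulfonyl group and both give numbers above that of compound 3, though each also differs from compound 4 elsewhere, so they fix no step of their own.

The expectation for compound 4 is a small rise, a 2.0-fold higher number from compound 3 to compound 4 (0.30 log units; within the scatter), possibly not beyond the scatter. Compound 4 is estimated at 4 nM in this assay, with a range from 1.5 nM to 10 nM.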

Compound 4, half-maximal inhibitory concentration: 5 nM
The estimate for compound 4 lay 1.3-fold (0.10 log units) below the measured number, and the stated range covers the measured number.
By their numbers in this assay, from the lowest: compound 3; then compounds 1, 2 and 4 (each within the scatter of the next).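

The change from (trifluoromethyl)sulfonyl to (difluoromethyl)sulfonyl now stands on its own as a 2.5-fold higher number from compound 3 to compound 4 (0.40 log units; beyond the scatter) in this assay and is a modest step, so hydrogen in place of fluoro on this carbon is enough to register beyond the scatter. With the (difluoromethyl)sulfonyl group held, fluoro in place of chloro on an aromatic carbon gives no change at the digits printed from compound 2 to compound 4 (within the scatter) and pyridin-4-yl in place of (1H-imidazol-1-yl)methyl on an aromatic carbon gives no change at the digits printed from compound 1 to compound 4 (within the scatter) and neither step leaves the scatter. Among these compounds, of the three single changes now readable, only the one on the sulfonyl group lies beyond the scatter, and that reading rests on a single pair.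

Nothing available explains why removing one fluorine moves the number. Still open, on these data alone, is whether the same step appears with chloro or (1H-imidazol-1-yl)methyl on the aromatic carbon, and how a plain methyl or an ethyl on the sulfonyl sulfur would compare with the two fluorinated groups.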